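The source may report more compounds than this note shows. Statements on the series, on what has been measured and on what is new or still open speak of the compounds shown alone.

Of the compounds shown here, three sharing one core have been tested in a functional assay on MDA-MB-231 cells (Homo sapiens) for cytotoxicity, read by MTT assay, with a stated time of 48 h; on this read-out higher numbers stand for weaker inhibition and lower numbers for stronger inhibition. Compound 1 `O=c1ccoc2cc(OCc3cn(Cc4cccc(F)c4)nn3)ccc12` gives > 100000 nM, which is a limit and not a number. Compound 2 `O=c1ccoc2cc(OCc3cn(Cc4cccc(Cl)c4)nn3)ccc12` gives > 100000 nM, again a limit. Compound 3 `O=c1ccoc2cc(OCc3cn(Cc4ccc(Br)cc4)nn3)ccc12` gives > 100000 nM, also only a limit. Compound 3 therefore has no numerical standing of its own, and it sits with the other two at the limit of > 100000 nM in this assay, at which 3 of the 3 values shown sit.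

The next compound, compound 4 `O=c1ccoc2cc(OCc3cn(Cc4ccccc4Br)nn3)ccc12`, has the same atoms as compound 3, joined differently: 2-bromophenyl in place of 4-bromophenyl on a saturated chain carbon bound to an aromatic nitrogen. In words, it carries 2-bromophenyl in place of 4-bromophenyl on a saturated chain carbon bound to an aromatic nitrogen.

The closest measured changes on this aryl group are a step that the two limits leave unreadable from compound 1 to compound 3 and a step that the two limits leave unreadable from compound 2 to compound 3, while the halogen swap is a step that the two limits leave unreadable from compound 1 to compound 2. None of them gives a size, so the data offer no sign that changing this group moves the read-out, and they give no direction for such a move. The expected change is therefore none beyond the scatter, and it is estimated as a number no higher from compound 3 to compound 4 (the limit leaves the size open). For compound 4 the estimated value is 100000 nM, within an expected range of 50000 nM to 200000 nM, and the assay may well report only a limit again.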

Compound 4, half-maximal inhibitory concentration: > 100000 nM
Compound 4: only a limit was reported; the forecaster's own chance of this, stated with the estimate: 85%; the middle value sits exactly at the limit.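

Compound 4 joins compound 1, compound 2 and compound 3 at one shared limit, so no step among these four compounds can be read: the limit of > 100000 nM in this assay, at which 4 of the 4 values shown sit.

The compounds shown leave open whether any change on this aryl group moves the read-out in this assay, and how far each of the four lies beyond that limit.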